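A few compounds are considered here, and "the series" means these few. Any claim that something is new, unique, unknown or untested is made for them only; others in the source may bear on it.

Working notes on the thiourea series.

The measured compounds share one core and a four-carbon chain ending in a thiourea; compound 1 `O=c1ccc(-c2ccccc2)nn1CCCCNC(=S)NC1CCCCC1` carries cyclohexyl on the amide-type nitrogen and compound 2 `O=c1ccc(-c2ccccc2)nn1CCCCNC(=S)Nc1ccccc1` carries phenyl there. In a functional assay on the whole organism with Rattus norvegicus as the target, at a dose of 100 mg/kg (on this read-out higher numbers stand for more inhibition at the one dose given (going by the name of the read-out) and lower numbers for less inhibition), compound 1 gives 18.1% and compound 2 gives 38.4%. For the measured compounds named here, the only step measured so far is a number 20.3 percentage points higher from compound 1 to compound 2 (beyond the scatter). Compound 2 therefore stands highest of the two numbers, with compound 1 the nearest and beyond the scatter below it.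

Compound 3 `O=c1ccc(-c2ccccc2)nn1CCCCNC(=S)Nc1cccc2ccccc12` differs from compound 2 in one place: naphthalen-1-yl in place of phenyl on an amide-type nitrogen. Going by the values given here, no measured step covers a change of this kind; the step from cyclohexyl to phenyl is the only one available, and it concerns a different exchange, so it sets no direction for adding a second aromatic ring. Compound 3 is expected to stay near compound 2, because compound 2 gives 38.4% and nothing measured points clearly up or down from it; the step of a number 3.6 percentage points higher from compound 2 to compound 3 (within the scatter) is thus expected to lie within the scatter. The estimate for compound 3 in this assay is 42%, with a range from 20% to 65%.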

Compound 3, a percentage reported as inhibition, in the whole organism at one dose (the size of the read-out at that dose, not a potency): 42.3%
The estimate for compound 3 lay 0.3 percentage points below the measured number, within the range that was stated.
By their numbers in this assay, from the lowest: compound 1; then compounds 2 and 3 (each within the scatter of the next).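

In this assay, naphthalen-1-yl in place of phenyl on the amide-type nitrogen gives a number 3.9 percentage points higher from compound 2 to compound 3 (within the scatter), so at this position a second six-membered aromatic ring of carbon only makes no difference that can be told from the scatter. Set against the cyclohexyl group, naphthalen-1-yl gives a number 24.2 percentage points higher from compound 1 to compound 3 (beyond the scatter), so the gap first seen with phenyl also holds for a second, larger aromatic group; across these compounds, both aromatic groups stand beyond the scatter above cyclohexyl, though three compounds are a narrow basis for any wider pattern. Nothing available bears on why the two aromatic groups read alike or why both differ from cyclohexyl.

The compounds shown leave open whether a phenyl ring carrying a substituent such as chlorine or methoxy, a benzyl group or a pyridine ring on this nitrogen would move the number beyond the scatter in either direction. They also leave open how much of the reading depends on the thiocarbonyl or on the four-carbon chain, for instance in a urea or a longer chain, and a single dose gives no potency for any of these compounds.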